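A few compounds are considered here, and "the series" means these few. Any claim that something is new, unique, unknown or untested is made for them only; others in the source may bear on it.

Compound 2 `COc1cc(Nc2ncnc3c(NC(=O)Nc4cccc(C)c4C)cccc23)cc(OC)c1` gives 5910 nM in a functional assay on RT-112 cells (Homo sapiens) for antiproliferative activity, read by MTT assay, with a stated time of 72 h (on this read-out lower numbers stand for stronger inhibition of growth and higher numbers for weaker inhibition of growth), the higher of the two numbers measured, while compound 1 `COc1cc(Nc2ncnc3c(NC(=O)Nc4cccc(Cl)c4Cl)cccc23)cc(OC)c1` gives 63.2 nM. Compound 3 `COc1cc(Nc2ncnc3c(NC(=O)Nc4ccc(C(F)(F)F)cc4Cl)cccc23)cc(OC)c1` has not been measured. It differs from compound 2 as 2-chloro-4-(trifluoromethyl)phenyl in place of 2,3-dimethylphenyl on an amide-type nitrogen. Among the measured compounds shown here, the one measured step, a 94-fold higher number from compound 1 to compound 2 (1.97 log units; beyond the scatter), came from replacing 2,3-dichlorophenyl with 2,3-dimethylphenyl on the amide-type nitrogen, a very large rise. Compound 3 brings a chlorine-bearing ring back to that nitrogen, so a large fall is expected, a 39-fold lower number from compound 2 to compound 3 (1.60 log units; beyond the scatter). Compound 3 is therefore estimated at 150 nM, between 30 nM and 800 nM.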

Compound 3, concentration for 50% growth inhibition: 1080 nM
For compound 3 the middle estimate is 7.2-fold (0.86 log units) below the measured one, and the stated range ends below it.
By their numbers in this assay, from the lowest: compound 1; then compound 3; then compound 2.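

Putting 2-chloro-4-(trifluoromethyl)phenyl on the amide-type nitrogen gives back only part of what the dimethyl ring lost, with a 5.5-fold lower number from compound 2 to compound 3 (0.74 log units; beyond the scatter) as the gain and a 17-fold higher number from compound 1 to compound 3 (1.23 log units; beyond the scatter) as the gap still left to the dichloro ring. A chlorine-bearing ring at this nitrogen is therefore not enough on its own, since the two such rings shown give clearly different numbers. No measurement here explains that difference. Still open, going by these compounds, is how this ring would behave with a methoxy group, an amine or a carboxylic acid on it, or with a single chlorine alone.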